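Putting methyl back, and more, on the saturated ring

The compounds below may be only part of what the source reports. "The series", "measured", "known", "first", "only" and "open" are said of these compounds alone.

Of the compounds shown here, three have been measured in a functional assay with growth hormone secretagogue receptor type 1 (Homo sapiens) as the target; a higher number here means a larger maximal response, a lower number a smaller maximal response. Compound 1 `COc1cc2c(cc1N1CCN[C@@H](C)C1)N(S(=O)(=O)c1ccc(-c3ccccn3)s1)CC2` gives 1, and compound 2 `COc1cc2c(cc1N1CCN[C@H](C)C1)N(S(=O)(=O)c1ccc(-c3ccccn3)s1)CC2` gives 1; these two share all atoms and bonds and differ only in the configuration as drawn, and no change at the digits printed from compound 1 to compound 2 (within the scatter), which fits with the fact that compounds 1 and 2 differ only in the configuration as drawn. Compound 3 `COc1cc2c(cc1N1CCNCC1)N(S(=O)(=O)c1ccc(-c3ccccn3)s1)CC2`, which carries hydrogen in place of the methyl on the saturated ring carbon, gives 0.8, the lowest of the three measured numbers. The steps show a number 0.20 lower from compound 1 to compound 3 (beyond the scatter) and a number 0.20 lower from compound 2 to compound 3 (beyond the scatter), so taking away that methyl lowered the maximal response by a modest amount beyond the scatter.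

Compound 4 `COc1cc2c(cc1N1C[C@@H](C)NC(C)(C)C1)N(S(=O)(=O)c1ccc(-c3ccccn3)s1)CC2` has not yet been measured. Compared with compound 3, the change is a group of 9 heavy atoms (7 carbon, 2 nitrogen; one six-membered non-aromatic ring with 2 hetero atoms) in place of a group of 6 heavy atoms (4 carbon, 2 nitrogen; one six-membered non-aromatic ring with 2 hetero atoms), on an aromatic carbon. Going by the values given here, the entering group brings back a methyl on a saturated ring carbon, as in compounds 1 and 2, and adds further carbons for which no measured counterpart exists here. The measured steps that bear on this are the two modest drops from compounds 1 and 2 to compound 3; reversing them points to a modest rise. The step a number 0.15 higher from compound 3 to compound 4 (beyond the scatter) is therefore expected to be modest and upward. Compound 4 is estimated to give 0.95, with a range from 0.75 to 1.1.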

Compound 4, intrinsic activity: the largest response reached, as a fraction of the reference agonist's: 0.8
Compound 4: the middle estimate sits 0.15 above what was measured, and the stated range covers the measured number.
By their numbers in this assay, from the lowest: compounds 3 and 4 (each within the scatter of the next); then compounds 1 and 2 (each within the scatter of the next).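

In this assay, the larger entering group gives no change at the digits printed from compound 3 to compound 4 (within the scatter), so at this position, adding carbons to the plain piperazin-1-yl ring does not by itself restore the fuller maximal response seen with a single methyl. The comparison with the single-methyl rings makes the same point, with a number 0.20 lower from compound 2 to compound 4 (beyond the scatter) and a number 0.20 lower from compound 1 to compound 4 (beyond the scatter), which shows that the effect of carbons on this saturated ring does not simply add up: the response does not keep rising as more are added, and compounds 1 and 2 remain the only ones here at the higher level. Nothing measured here explains why the further carbons cancel the gain that came with one methyl.

The compounds shown cannot separate the contribution of the further carbons from that of the defined stereocentre in the entering group, since a ring with only those further carbons and the mirror-image form of compound 4 are both absent from this set. As far as these compounds go, what an ethyl group on the saturated ring, or an acetyl group on its nitrogen, would do to the maximal response also remains open.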